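Urea Analogues on a Benzimidazole-Bearing Core: Compound 3 Forecast

This account rests on a few compounds, and the source may have more. Where it says the series, first, only, none or still open, it means among the compounds named here.

Measured compounds:
compound 1 `Cc1ccc(NC(=S)NC(=O)c2ccc(OCc3ccc(Cl)cc3Cl)cc2)cc1-c1nc2ccccc2[nH]1` — 11600 nM
compound 2 `Cc1ccc(NC(=O)NC(=O)c2ccc(OCc3cccc(C(F)(F)F)c3)cc2)cc1-c1nc2ccccc2[nH]1` — 3520 nM

In a functional assay on HT-29 cells (Homo sapiens) for inhibition, read by MTT assay, with a stated time of 48 h (on this read-out higher numbers stand for weaker inhibition and lower numbers for stronger inhibition), compound 2 gives 3520 nM. Of the two numbers recorded, compound 2 holds the lower one; compound 1 gives 11600 nM in this assay, a higher number that lies beyond the scatter. Compound 1 and compound 2 differ in more than one place, so their two values are set side by side without any single change being credited. Compound 3 `Cc1ccc(NC(=O)NC(=O)c2ccc(OCc3ccc(Cl)cc3Cl)cc2)cc1-c1nc2ccccc2[nH]1` has not been measured. It differs from compound 2 in one place: 2,4-dichlorophenyl in place of 3-(trifluoromethyl)phenyl on a saturated chain carbon bound to an oxygen on an aromatic ring. Going by the values given here, no measured pair shows this change alone. The nearest guide is compound 1, which carries the same 2,4-dichlorobenzyl group and gives 11600 nM. Compound 3 is therefore expected to land between the two measured values, with a step of a 1.6-fold higher number from compound 2 to compound 3 (0.19 log units; within the scatter) toward a higher number. The estimate for compound 3 is 5500 nM, within 1800 nM to 16000 nM.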

Compound 3, half-maximal inhibitory concentration: 2620 nM
Compound 3: middle estimate off by 2.1-fold (0.32 log units), on the high side; low and high end bracket the measured number.
By their numbers in this assay, from the lowest: compounds 3 and 2 (each within the scatter of the next); then compound 1.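

In this assay, going by these compounds alone, placing 2,4-dichlorophenyl where 3-(trifluoromethyl)phenyl stood, on a saturated chain carbon bound to an oxygen on an aromatic ring, gives a 1.3-fold lower number from compound 2 to compound 3 (0.13 log units; within the scatter) as the first reading of this change alone. On the urea series, then, this read-out does not separate the two substituted benzyl groups, although the entering group has fewer heavy atoms and carries chlorine in place of fluorine. No measurement at hand accounts for this result.

The compounds shown leave open whether the position would hold this level with an unsubstituted benzyl, a benzyl bearing an amine or a carboxylic acid, or a longer chain to the aromatic ring. They also leave open how 3-(trifluoromethyl)benzyl would read on the thiourea form of the shared core.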